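Methylating the Indole Nitrogen on a Long-Chain Amide

The source may hold more compounds than are shown below. What is called first, only, known or untested is meant among the compounds shown, and "the series" means these compounds.

Compound 1 `CCCCCCCCCCCCNC(=O)[C@@H](NC(=O)c1cc2ccccc2n1C)[C@@H](C)O`: > 200000 nM in a functional assay on SW-620 cells (Homo sapiens) for cytotoxicity, read by MTT assay, with a stated time of 48 h (on this read-out higher numbers stand for weaker inhibition and lower numbers for stronger inhibition), a limit of the assay.
Compound 2 `CCCCCCCCCCCCCCCCCCNC(=O)[C@@H](NC(=O)c1cc2ccccc2o1)[C@@H](C)O`: > 200000 nM, a limit of the assay.
Compound 3 `CCCCCCCCCCCCCCCCCCNC(=O)[C@@H](NC(=O)c1cc2ccccc2[nH]1)[C@@H](C)O`: 23600 nM.

Among the compounds with values here, compound 3 gives the only actual number here; the other two entries are limits, not numbers. Compound 4 `CCCCCCCCCCCCCCCCCCNC(=O)[C@@H](NC(=O)c1cc2ccccc2n1C)[C@@H](C)O` differs from compound 3 by methyl in place of hydrogen on an aromatic nitrogen. Within the data shown here, no measured step makes exactly this change. The nearest is an at least 8.4-fold lower number from compound 2 to compound 3 (0.92 log units; beyond the scatter), which shows that the form with a hydrogen on the aromatic nitrogen gives the lower number. Compound 2 sits at the limit of > 200000 nM in this assay, at which 2 of the 3 values shown sit. Compound 1, which already carries the methylated nitrogen on a shorter chain, also gives only a limit. Removing that hydrogen in compound 4 is therefore expected to raise the number, and compound 4 is estimated at 150000 nM, with a range from 40000 nM to 400000 nM. This is expected to be a step of a 6.4-fold higher number from compound 3 to compound 4 (0.80 log units; beyond the scatter).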

Compound 4, half-maximal inhibitory concentration: 124000 nM
Compound 4: the middle estimate sits 1.2-fold (0.08 log units) above what was measured, and the stated range covers the measured number.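

In this assay, within the data shown here, methyl in place of hydrogen on the aromatic nitrogen gives a 5.3-fold higher number from compound 3 to compound 4 (0.72 log units; beyond the scatter), the first direct reading of this change with the chain held constant. Compound 4 still gives an actual number, so the methylated form keeps measurable activity, but the comparisons with the two limit compounds are only floors: an at least 1.6-fold lower number from compound 2 to compound 4 (0.20 log units; that floor lies within the scatter) and an at least 1.6-fold lower number from compound 1 to compound 4 (0.20 log units; that floor lies within the scatter). Those two compounds give no number to compare against: the limit of > 200000 nM in this assay, at which 2 of the 4 values shown sit.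

The size of the chain's contribution therefore stays unresolved. As far as these compounds go, whether an ethyl group on that nitrogen, or a longer chain, would shift the number also remains open.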